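Capping One Hydroxy Group of Compound 1

The compounds below may be only part of what the source reports. "The series", "measured", "known", "first", "only" and "open" are said of these compounds alone.

Going by the values given here, in a functional assay on HCC 2998 cells (Homo sapiens) for cytotoxicity, read by sulforhodamine B assay, with a stated time of 48 h (a lower number here means a stronger inhibitor of growth, a higher number a weaker inhibitor of growth), compound 1 `COc1cc(C(=O)c2ccc(OC)c(O)c2OC)cc(OC)c1O` gives 2890 nM and so holds the lower of the two numbers so far, while compound 2 `COc1cc(C(=O)c2ccc3c(c2)oc(=O)n3S(C)(=O)=O)cc(OC)c1OC` gives 6750 nM and lies beyond the scatter from it. Compound 3 `COc1ccc(C(=O)c2cc(OC)c(OC)c(OC)c2)c(OC)c1O` differs from compound 1 in one place, hydroxy to methoxy, with methyl in place of hydrogen on an oxygen on an aromatic ring. Among the compounds with values here, no measured pair shows this change, so its size remains uncertain. The expected step is a 12-fold lower number from compound 1 to compound 3 (1.06 log units; beyond the scatter) and lies beyond the scatter, towards stronger inhibition of growth. In this assay compound 3 is estimated at 250 nM (expected range 30 nM to 2500 nM).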

Compound 3, concentration for 50% growth inhibition: 211 nM
Compound 3: middle estimate off by 1.2-fold (0.07 log units), on the high side, within the range that was stated.
By their numbers in this assay, from the lowest: compound 3; then compound 1; then compound 2.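

In this assay, going by these compounds alone, there is a 14-fold lower number from compound 1 to compound 3 (1.14 log units; beyond the scatter) when methyl takes the place of hydrogen on this oxygen on an aromatic ring, the first single change that can be read here. A free hydroxy group at this position is therefore not needed for inhibition of growth in these cells, and the methoxy compound is clearly the stronger of the pair. No available evidence explains the size of this step. The compounds shown leave open whether ethyl or a longer chain on this oxygen would act like methyl, and what an amine in place of the hydroxy group would do.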